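The compounds below may be only part of what the source reports. "The series", "measured", "known", "first", "only" and "open" are said of these compounds alone.

In a functional assay on Caco-2 cells (Homo sapiens) for inhibition, read by MTT assay, with a stated time of 48 h, tested at 10 uM (on this read-out higher numbers stand for more inhibition of growth at the one concentration tested and lower numbers for less inhibition of growth), compound 1 `CN1CC[C@H](c2c(O)cc(O)c3c(=O)cc(/C=C/c4cccc(Cl)c4)oc23)[C@H](O)C1` gives 55%, and compound 2 `CN1CC[C@H](c2c(O)cc(O)c3c(=O)cc(/C=C/c4c(F)c(F)c(F)c(F)c4F)oc23)[C@H](O)C1` gives 59%, so compound 2 stands level with compound 1 within the scatter. The next compound, compound 3 `CN1CC[C@H](c2c(O)cc(O)c3c(=O)cc(/C=C/c4cccc(F)c4)oc23)[C@H](O)C1`, keeps the core of compound 2 and differs from it in one place: 3-fluorophenyl in place of 2,3,4,5,6-pentafluorophenyl on a double-bonded chain carbon bound to a double-bonded chain carbon. Here 3-fluorophenyl comes in place of 2,3,4,5,6-pentafluorophenyl on a double-bonded chain carbon bound to a double-bonded chain carbon. Within the data shown here, only one measured step bears on this, a swap at the same place: a number 4 percentage points higher from compound 1 to compound 2 (within the scatter). That single step is thin evidence, but it gives no sign that this place moves the number much. The estimated step is a number 3 percentage points lower from compound 2 to compound 3 (within the scatter), which means no change beyond the scatter is expected. For compound 3 the estimated value is 56%, with an expected range from 44% to 68%.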

Compound 3, percent growth inhibition at one concentration: 61%
Compound 3: middle estimate off by 5 percentage points, on the low side, within the range that was stated.
By their numbers in this assay, from the lowest: compounds 1, 2 and 3 (each within the scatter of the next).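

In this assay, 3-fluorophenyl in place of 2,3,4,5,6-pentafluorophenyl gives a number 2 percentage points higher from compound 2 to compound 3 (within the scatter), so a much less heavily fluorinated ring leaves the read-out level. The change of fluoro in place of chloro on an aromatic carbon gives a number 6 percentage points higher from compound 1 to compound 3 (within the scatter), which adds a direct comparison of these two halogens on the ring and likewise shows no change beyond the scatter. Nothing available explains why these three rings read alike.

Still open, on these data alone, is whether this place stays as undemanding with a group other than a halogen on the ring, such as an amine or a carboxylic acid. A reading at a single concentration also leaves open whether these three compounds would separate at other concentrations.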